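This account rests on a few compounds, and the source may have more. Where it says the series, first, only, none or still open, it means among the compounds named here.

Series notes. Compound 1 `O=C(O)/C=C/C(=O)Nc1cccc(-c2nc3ccccc3s2)c1`, compound 2 `CN(C)CCC(=O)Nc1cccc(-c2nc3ccccc3s2)c1` and compound 3 `O=C(Nc1cccc(-c2nc3ccccc3s2)c1)c1cccnc1Cl` share one core and differ only in the group on the carbonyl carbon. In an ADME assay on Raji cells (Homo sapiens) for inhibition, with a stated time of 72 h (on this read-out higher numbers stand for an effect only at larger amounts of compound and lower numbers for an effect already at smaller amounts), compound 1 gives only a limit of the assay, > 25000 nM. Compound 2 likewise reaches only a limit, > 25000 nM. Compound 3 also sits at a limit, > 25000 nM. The steps a step that the two limits leave unreadable from compound 1 to compound 2, a step that the two limits leave unreadable from compound 1 to compound 3 and a step that the two limits leave unreadable from compound 2 to compound 3 are therefore unreadable in size, because of the limit of > 25000 nM in this assay, at which 3 of the 3 values shown sit. Compound 4 `O=C(Nc1cccc(-c2nc3ccccc3s2)c1)c1ccnc(Cl)c1` is the next member and differs from compound 3 by 2-chloropyridin-4-yl in place of 2-chloropyridin-3-yl on a carbonyl carbon. Going by the values given here, no measured step shows this kind of change, and none of the three gives a readable size to lean on. Compound 4 is therefore expected to show a step that the limit leaves unreadable from compound 3 to compound 4, most likely ending again at a limit. The estimate for compound 4 is 30000 nM, with an expected range from 10000 nM to 100000 nM.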

Compound 4, half-maximal effective concentration: > 25000 nM
Compound 4 was reported as a limit; the forecaster's own chance of this, stated with the estimate: 85%; the middle value is on the limit's open side.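

In this assay compound 4 again gives only a limit, > 25000 nM. No new step can be read between compound 4 and compound 1, compound 2 or compound 3: the limit of > 25000 nM in this assay, at which 4 of the 4 values shown sit. The compounds shown leave open whether any group on the carbonyl carbon changes this read-out at all.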